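Spirocyclic amide series: piperazine amide replacing aminoethyl amide

The source may hold more compounds than are shown below. What is called first, only, known or untested is meant among the compounds shown, and "the series" means these compounds.

Measured so far:
compound 1, `CC(C)(C)OC(=O)NC1CCCN(C(=O)CN2CN(c3ccccc3)C3(CCN(C(=O)c4ccc(C(C)(C)C)cc4)CC3)C2=O)C1`: 4200 nM
compound 2, `CC(C)(C)c1ccc(C(=O)N2CCC3(CC2)C(=O)N(CC(=O)NCCN)CN3c2ccccc2)cc1`: 7000 nM
compound 3, `CC(C)(C)OC(=O)NCCCCNC(=O)CN1CN(c2ccccc2)C2(CCN(C(=O)c3ccc(C4CCCCC4)cc3)CC2)C1=O`: 4600 nM

In an assay on HEK293 cells for displacement of a labelled ligand from NPC1-like intracellular cholesterol transporter 1 (Homo sapiens) (a lower number here means a stronger inhibitor, a higher number a weaker inhibitor), compound 1 gives 4200 nM, compound 3 gives 4600 nM, and compound 2 gives 7000 nM. Compound 2 returns the largest of the three numbers, but the gaps to compound 3 and to compound 1 both lie within the usual scatter, so the three compounds cannot be separated on these data. Going by the values given here, no pair of the measured compounds differs in a single place, so no step between them is available to lean on.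

Compound 4, `CC(C)(C)c1ccc(C(=O)N2CCC3(CC2)C(=O)N(CC(=O)N2CCNCC2)CN3c2ccccc2)cc1`, is the next compound of the series to be measured in this assay. Relative to compound 2 the change is piperazin-1-yl in place of (2-aminoethyl)amino on a carbonyl carbon. The carbonyl that carries the change sits on a saturated chain carbon of the shared core; everything else in compound 4 is the same as in compound 2.

Among the compounds with values here, with no measured step of this kind and the three known values lying within the scatter of one another, the step from compound 2 to compound 4 is expected to be small, in neither direction beyond the scatter: a 1.2-fold lower number from compound 2 to compound 4 (0.07 log units; within the scatter). Compound 4 is therefore estimated at 6000 nM, with a range from 2500 nM to 15000 nM.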

Compound 4, half-maximal inhibitory concentration: 22000 nM
Compound 4: the middle estimate sits 3.7-fold (0.56 log units) below what was measured; the whole stated range lies below it.
By their numbers in this assay, from the lowest: compounds 1, 3 and 2 (each within the scatter of the next); then compound 4.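

In this assay, going by these compounds alone, piperazin-1-yl in place of (2-aminoethyl)amino on a carbonyl carbon gives a 3.1-fold higher number from compound 2 to compound 4 (0.50 log units; beyond the scatter), so this position is sensitive to the group it carries, which the three earlier values, all within the scatter of one another and with no single-place step among them, could not show. The change brings in one six-membered non-aromatic ring with 2 hetero atoms, raises the heavy atoms of the group from 4 to 6 and lowers its hydrogen-bond donors from 2 to 1, and this one step does not separate these differences. Nothing at hand accounts for the size or direction of the step.

On these data alone, it remains open which of these differences carries the step; on the same carbonyl carbon, morpholin-4-yl, piperidin-1-yl or a longer chain such as (3-aminopropyl)amino would help to separate them. As far as these compounds go, it is also open whether the same exchange gives a step of similar size with the cyclohexyl group of compound 3 in place of the tert-butyl group of compound 2.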